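Taking the nitro group off compound 2

The compounds below may be only part of what the source reports. "The series", "measured", "known", "first", "only" and "open" are said of these compounds alone.

Among the measured compounds shown here, in a functional assay on L1210 cells (Mus musculus) for antiproliferative activity, read by MTT assay, with a stated time of 72 h (on this read-out higher numbers stand for weaker inhibition and lower numbers for stronger inhibition), compound 2 `COc1ccc(C2=NN(C(C)=O)C(c3cccc([N+](=O)[O-])c3)O2)cc1` gives 47000 nM, the higher of the two exact numbers so far. The other exact number belongs to compound 1 `COc1cc(C2=NN(C(C)=O)C(c3ccc([N+](=O)[O-])cc3)O2)cc(OC)c1OC`, which gives a clearly lower 4200 nM. Compound 3 `COc1ccc(C2=NN(C(C)=O)C(c3ccc(OC)c([N+](=O)[O-])c3)O2)cc1` gives only a limit, > 100000 nM.

The next compound, compound 4 `COc1ccc(C2=NN(C(C)=O)C(c3ccccc3)O2)cc1`, differs from compound 2 in one place: hydrogen in place of nitro on an aromatic carbon. Put simply, hydrogen stands in place of nitro on an aromatic carbon, meta to a large group. For the measured compounds named here, no measured step makes this exact change. The closest evidence is an at least 2.1-fold higher number from compound 2 to compound 3 (0.32 log units; beyond the scatter), where methoxy replaces hydrogen on an aromatic carbon of the same ring. Going by the values given here, that step keeps the nitro group, so it shows only that a change on this ring can shift the number, not what losing nitro does. Compound 1 carries a nitro group too, but it differs from compound 2 in other places as well, so its value cannot isolate that group.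

With no firm direction available, only a small change is expected in this assay, probably within the scatter. The expected change is a 1.1-fold higher number from compound 2 to compound 4 (0.03 log units; within the scatter). A result at the limit of > 100000 nM in this assay, at which 1 of the 3 values shown sits, also remains possible. For compound 4, the estimated value is 50000 nM, with an expected range from 17000 nM to 100000 nM.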

Compound 4, half-maximal inhibitory concentration: > 100000 nM
Compound 4 was reported as a limit (the forecaster's own chance of this, stated with the estimate: 30%); middle value at least 2.0-fold (0.30 log units) away from the limit.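

Hydrogen in place of nitro gives an at least 2.1-fold higher number from compound 2 to compound 4 (0.32 log units; beyond the scatter) in this assay and so this change, on an aromatic carbon meta to a large group, weakens inhibition rather than leaving it nearly unchanged. Compound 4 gives > 100000 nM and this is a limit of the assay, not a number. Until now the only single change shown on this ring was the added methoxy group of compound 3, with the nitro group kept, and now both single changes to this ring of compound 2, adding methoxy and removing nitro, end at the same limit: the limit of > 100000 nM in this assay, at which 2 of the 4 values shown sit.

On these data alone, whether an amine or a nitrile in the same place would keep the number of compound 2 or lose it stays open, so the result does not tell whether nitro itself is needed there or whether another group could serve. Also open, as far as these compounds go, is whether taking the nitro group off compound 1 would weaken inhibition in the same way, and how compound 3 and compound 4 compare with each other, since neither has an exact number.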